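Same Atoms, New Arrangement: From Compound 3 to Compound 4

The compounds below may be only part of what the source reports. "The series", "measured", "known", "first", "only" and "open" are said of these compounds alone.

Three related compounds have been measured in an ADME assay on L02 cells (Homo sapiens) for inhibition, read by CCK-8 assay, with a stated time of 48 h; on this read-out lower numbers stand for stronger inhibition of growth and higher numbers for weaker inhibition of growth. Compound 1 (`COc1ccc(CNc2nc(Nc3ccc(N4CCN(C)CC4)cn3)ncc2Cl)cc1`) gives 12900 nM. Compound 2 (`CCc1ccc(Nc2nc(Nc3ccc(N4CCN(C)CC4)cn3)ncc2Cl)cc1`) gives 12100 nM. Compound 3 (`CC(C)c1cccc(Nc2nc(Nc3ccc(N4CCN(C)CC4)cn3)ncc2Cl)c1`) gives 12500 nM, so on these numbers it cannot be told apart from the other two.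

The steps between them show this. Putting 4-ethylphenyl in place of 4-methoxybenzyl gives a 1.1-fold lower number from compound 1 to compound 2 (0.03 log units; within the scatter). Putting 3-isopropylphenyl in that same place gives a 1.0-fold lower number from compound 1 to compound 3 (0.01 log units; within the scatter). Exchanging those two phenyl groups gives a 1.0-fold higher number from compound 2 to compound 3 (0.01 log units; within the scatter). All three steps lie within the scatter.

Compound 4 (`Cc1cc(C)c(Nc2nc(Nc3ccc(N4CCN(C)CC4)cn3)ncc2Cl)c(C)c1`) has not yet been measured. It carries 2,4,6-trimethylphenyl in place of 3-isopropylphenyl on a nitrogen on an aromatic ring. The two compounds have the same atoms, joined differently.

Among the measured compounds shown here, no measured compound carries the 2,4,6-trimethylphenyl group, so the evidence is indirect. For the measured compounds named here, the closest precedent is a 1.0-fold higher number from compound 2 to compound 3 (0.01 log units; within the scatter), another exchange of one substituted phenyl group for another, and it produced no real change. A step beyond the scatter is therefore not expected here. The expected result is a 1.0-fold lower number from compound 3 to compound 4 (0.02 log units; within the scatter). For compound 4 the estimated value is 12000 nM, with an expected range from 6500 nM to 22000 nM.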

Compound 4, concentration for 50% growth inhibition: 20500 nM
Compound 4: middle estimate off by 1.7-fold (0.23 log units), on the low side, within the range that was stated.
By their numbers in this assay, from the lowest: compounds 2, 3, 1 and 4 (each within the scatter of the next).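

On the nitrogen that carries these groups, putting 2,4,6-trimethylphenyl in place of 3-isopropylphenyl in this assay gives a 1.6-fold higher number from compound 3 to compound 4 (0.21 log units; within the scatter), so these two arrangements of the same atoms cannot be told apart on this read-out. Among the compounds shown here, the comparisons with the other two compounds read the same way, with a 1.7-fold higher number from compound 2 to compound 4 (0.23 log units; within the scatter) and a 1.6-fold higher number from compound 1 to compound 4 (0.20 log units; within the scatter), which means that these steps are larger than any seen among the earlier compounds, yet all four compounds still form one group within the scatter, now including a substitution pattern that no earlier compound carried. Nothing among the data shown explains the size of these steps.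

With no step beyond the scatter so far, the compounds shown do not reveal what at this position, if anything, affects the number. As far as these compounds go, it remains open whether an amine or a carboxylic acid on the phenyl ring, or a longer chain in place of that ring, would produce a step beyond the scatter.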